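Cyclopropyl ketone to cyclopropyl amide on the shared core

The source may report more compounds than this note shows. Statements on the series, on what has been measured and on what is new or still open speak of the compounds shown alone.

Compound 1 `O=C(c1ccc2c(c1)CC(c1nc3ccc(-c4cn[nH]c4)cc3c(=O)[nH]1)CO2)C1CC1` gives 18 nM in an assay on isolated protein for inhibition of Rho-associated protein kinase 2 (Homo sapiens), read by HTRF (on this read-out higher numbers stand for weaker inhibition and lower numbers for stronger inhibition), and holds the lowest number among the two measured values. Compound 2 `COc1ccc2c(c1)CC(c1nc3c(N(C)CCN(C)C)cc(-c4cn[nH]c4)cc3c(=O)[nH]1)CO2` gives 21 nM in this assay, within the scatter of compound 1. Compound 3 `O=c1[nH]c(C2=Cc3ccccc3OC2)nc2ccc(-c3cn[nH]c3)cc12` returns only a limit, > 5000 nM in this assay, as noted in the limit of > 5000 nM in this assay, at which 1 of the 3 values shown sits. Compound 4 `O=C(NC1CC1)c1ccc2c(c1)CC(c1nc3ccc(-c4cn[nH]c4)cc3c(=O)[nH]1)CO2` is not yet measured. It differs from compound 1 by cyclopropylamino in place of cyclopropyl on a carbonyl carbon, turning the cyclopropylcarbonyl into a cyclopropylcarbamoyl. For the measured compounds named here, no measured pair shows this change, so the step is expected to stay small, with no clear direction beyond the scatter. Compound 4 is estimated at 25 nM in this assay, between 8 nM and 80 nM. The expected step of a 1.4-fold higher number from compound 1 to compound 4 (0.14 log units; within the scatter) is modest.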

Compound 4, half-maximal inhibitory concentration: 1 nM
Compound 4: middle estimate off by 25-fold (1.40 log units), on the high side; the whole stated range lies above it.
By their numbers in this assay, from the lowest: compound 4; then compounds 1 and 2 (each within the scatter of the next). At a limit, above all of these: compound 3.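

In this assay, for the compounds shown here, cyclopropylamino in place of cyclopropyl on a carbonyl carbon gives an 18-fold lower number from compound 1 to compound 4 (1.26 log units; beyond the scatter) and so shows that the result at this position depends strongly on the group carried by the carbonyl, which the earlier compounds could not show. The change adds a nitrogen and a hydrogen-bond donor, and this single pair cannot separate the two. Nothing measured here bears on the reason for the step.

On these data alone, whether the amide hydrogen is needed remains open, and a tertiary amide with a methyl on the nitrogen would address this. As far as these compounds go, the reach of the group also remains open, for example methylamino or a longer chain such as butylamino on the same carbonyl carbon.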